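Replacing a Large Ring Group With Piperidine at the Chain End

The compounds below may be only part of what the source reports. "The series", "measured", "known", "first", "only" and "open" are said of these compounds alone.

Three compounds have been measured in a functional assay on HEK293 cells for agonist activity at 5-hydroxytryptamine receptor 4 (Homo sapiens), read by cAMP accumulation; on this read-out lower numbers stand for an effect already at smaller amounts and higher numbers for an effect only at larger amounts of compound:

Compound 1 `COc1cc(N)c(Cl)cc1C(=O)NC1CCN(CCCCCO)CC1`: 15.9 nM
Compound 2 `COc1cc(N)c(Cl)cc1C(=O)NC1CCN(CCCCCN2C(=O)c3ccccc3C2=O)CC1`: 5.01 nM
Compound 3 `COc1cc(N)c(Cl)cc1C(=O)NC1CCN(CCCCCCCCN2C(=O)c3ccccc3C2=O)CC1`: 3.16 nM

Compound 2 stands second highest of these three numbers. Compound 3 gives a lower number than compound 2, but the two lie within the scatter of each other, so they cannot be told apart. Compound 1 gives a clearly higher number: a 3.2-fold lower number from compound 1 to compound 2 (0.50 log units; beyond the scatter).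

Compound 4 `COc1cc(N)c(Cl)cc1C(=O)NC1CCN(CCCCCN2CCCCC2)CC1` differs from compound 2 in one place: a group of 6 heavy atoms (5 carbon, 1 nitrogen; one six-membered non-aromatic ring with 1 hetero atom) in place of a group of 11 heavy atoms (8 carbon, 1 nitrogen, 2 oxygen; one five-membered non-aromatic ring with 1 hetero atom, one six-membered aromatic ring of carbon only), on a saturated chain carbon, five bonds along the chain from an amine nitrogen in a ring. Among the measured compounds shown here, the only measured step that touches this position is the one from compound 1 to compound 2, where a single oxygen atom was exchanged for the larger group and the number fell modestly. Compound 4 carries a group that is smaller than that of compound 2 but larger than the oxygen of compound 1, so a number close to that of compound 2, perhaps somewhat higher, is expected, with the step of a 1.6-fold higher number from compound 2 to compound 4 (0.20 log units; within the scatter) probably no larger than the scatter. For compound 4 the estimate in this assay is 8 nM, expected to fall between 2 nM and 30 nM.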

Compound 4, half-maximal effective concentration: 5.01 nM
The estimate for compound 4 lay 1.6-fold (0.20 log units) above the measured number, within the range that was stated.
By their numbers in this assay, from the lowest: compounds 3, 2 and 4 (each within the scatter of the next); then compound 1.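

In this assay, the chain carbon five bonds along the chain from an amine nitrogen in a ring accepts piperidin-1-yl in place of the group of 11 heavy atoms, with no change at the digits printed from compound 2 to compound 4 (within the scatter). Piperidin-1-yl in place of hydroxy gives a 3.2-fold lower number from compound 1 to compound 4 (0.50 log units; beyond the scatter), a step of the same size as a 3.2-fold lower number from compound 1 to compound 2 (0.50 log units; beyond the scatter), so the lower number relative to compound 1 does not require the six-membered aromatic ring or the double bonds outside aromatic rings that compound 2 carries. No supporting data bear on why these two different groups give the same number.

As far as these compounds go, whether this lower number needs a ring or a nitrogen at this place remains open: an open-chain dimethylamino group or a cyclohexyl group could separate the two. Also open, from the compounds shown here alone, is how piperidin-1-yl behaves on a longer chain.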